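Thiosemicarbazone series: bromo removal from compound 3

A few compounds are considered here, and "the series" means these few. Any claim that something is new, unique, unknown or untested is made for them only; others in the source may bear on it.

Compound 1 `O=C1CS/C(=N/N=C/c2c[nH]c3ccccc23)N1c1cccc2ccccc12`: 34900 nM
Compound 2 `Cc1ccc(NC(=S)N/N=C/c2c[nH]c3ccccc23)cc1`: 2520 nM
Compound 3 `S=C(N/N=C/c1c[nH]c2ccc(Br)cc12)Nc1cccc2ccccc12`: 950 nM

Of the compounds shown here, three have numbers so far in a functional assay on MCF7 cells (Homo sapiens) for inhibition, read by spectrophotometry and sulforhodamine B assay, with a stated time of 48 h; on this read-out lower numbers stand for stronger inhibition of growth and higher numbers for weaker inhibition of growth. Compound 1 gives 34900 nM in this assay, compound 2 gives 2520 nM, and compound 3 gives 950 nM. Compound 3 stands lowest of the three; its nearest neighbour is compound 2, and the gap between them lies beyond the scatter, as does the much wider gap to compound 1.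

Compound 4 `S=C(N/N=C/c1c[nH]c2ccccc12)Nc1cccc2ccccc12` is the next member to be measured. It differs from compound 3 in one place: hydrogen in place of bromo on an aromatic carbon. Within the data shown here, no step between two measured compounds isolates this change, so the expectation rests on the values of compound 3 and compound 2 alone. Compound 3 gives 950 nM in this assay and carries the bromo; compound 2, which carries no bromo on its aromatic ring, gives 2520 nM.

For compound 4 a step of moderate size toward weaker inhibition of growth is expected, a 2.1-fold higher number from compound 3 to compound 4 (0.32 log units; beyond the scatter). The estimated value for compound 4 in this assay is 2000 nM, with a range from 700 nM to 6000 nM.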

Compound 4, concentration for 50% growth inhibition: 250 nM
For compound 4 the middle estimate is 8.0-fold (0.90 log units) above the measured one, and the stated range ends above it.
By their numbers in this assay, from the lowest: compound 4; then compound 3; then compound 2; then compound 1.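

In this assay the change from bromo to hydrogen gives a 3.8-fold lower number from compound 3 to compound 4 (0.58 log units; beyond the scatter) and so shows that, at this aromatic carbon, meta to a fused ring and para to a fused ring, hydrogen goes with stronger inhibition of growth than bromo. Among these compounds, this is the first single-place comparison, and it shows that the bromo is not needed for the activity of compound 3. No measurement shown accounts for the direction of this step.

From the compounds shown here alone, it remains open whether fluoro, chloro, methoxy or an amine at this position would give a number nearer that of compound 4 or that of compound 3. Going by these compounds, it also remains open whether bromo has the same effect at this position when the rest of the molecule is that of compound 2.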